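Swapping a propyl for a fluorinated ether on the piperidine carbonyl

This account rests on a few compounds, and the source may have more. Where it says the series, first, only, none or still open, it means among the compounds named here.

Compound 1 `CCCC(=O)N1CCC(N2CCN(C(=O)c3c(NC(=O)NCC)sc4ccccc34)CC2)CC1` stands in a functional assay on HepG2 cells (Homo sapiens) for inhibition, read by scintillation counting, with a stated time of 2 h (on this read-out lower numbers stand for stronger inhibition and higher numbers for weaker inhibition), as "not determined" (no result reported), so it gives no anchor. A close relative, compound 2 `CCNC(=O)Nc1sc2ccccc2c1C(=O)N1CCN(C2CCN(C(=O)NC(C)(C)C)CC2)CC1`, gives 775 nM in this assay. Compound 3 `CCNC(=O)Nc1sc2ccccc2c1C(=O)N1CCN(C2CCN(C(=O)OC(C)(C)C(F)(F)F)CC2)CC1` is compound 1 altered at one place: 1-methyl-1-(trifluoromethyl)ethoxy in place of propyl on a carbonyl carbon. For the measured compounds named here, with no measured step between these compounds, the size of the change in this assay cannot be judged from compound 1; the only guide is compound 2, whose value 775 nM sits close in structure. Compound 3 is therefore expected to land near 600 nM, with a range from 150 nM to 2500 nM.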

Compound 3, half-maximal inhibitory concentration: 81 nM
Beside the measured number, compound 3's estimate is 7.4-fold (0.87 log units) above it; measured number outside the range, below it.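

In this assay the group on this carbonyl carbon clearly counts: 1-methyl-1-(trifluoromethyl)ethoxy in place of (tert-butyl)amino gives a 9.6-fold lower number from compound 2 to compound 3 (0.98 log units; beyond the scatter) and so stronger inhibition, by a step beyond the scatter. Compound 1 has no number, so the swap from propyl cannot be read. Nothing shown gives a reason for the step from the amino group to the ether. Still open, from the compounds shown here alone, is how much of this step belongs to the ether oxygen and how much to the trifluoromethyl: a tert-butoxy group on the same carbonyl carbon would separate the two. Going by these compounds, how a longer chain would behave there also remains unknown.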